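This account rests on a few compounds, and the source may have more. Where it says the series, first, only, none or still open, it means among the compounds named here.

Measured in a physicochemical assay, read by spectrophotometry, with a stated time of 15 min; on this read-out lower numbers stand for stronger inhibition and higher numbers for weaker inhibition:

compound 1 `COc1cc(/C=N/NC(=O)CCCc2nc3ccccc3c(=O)[nH]2)cc(OC)c1OC` gives 85000000 nM
compound 2 `COc1cc(/C=N/NC(=O)CCCc2nc3ccccc3c(=O)[nH]2)ccc1O` gives 280000000 nM

Among the measured compounds shown here, these are the only two numbers so far. Compound 2 has the higher of them, so it is the weaker inhibitor of the pair, and its gap to compound 1 lies beyond the usual scatter of repeat measurements.

Compound 3 `COc1cc(/C=N/NC(=O)CCCc2nc3ccccc3c(=O)[nH]2)cc(O)c1O` is compound 2 with one change (hydroxy in place of hydrogen on an aromatic carbon). A hydroxy group takes the place of a hydrogen on an aromatic carbon, ortho to a hydroxy group and meta to a methoxy group.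

For the measured compounds named here, no pair of measured compounds differs in just one place, so nothing shows directly what this kind of change does. Going by the values given here, the only guide is that compound 1 at 85000000 nM reads lower than the other measured compound, which leaves room for a lower number on this core. A modest move towards stronger inhibition is therefore expected, with real uncertainty. The expected change is a 4.0-fold lower number from compound 2 to compound 3 (0.60 log units; beyond the scatter) in this test. Compound 3 is estimated at 70000000 nM (range 15000000 nM to 300000000 nM).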

Compound 3, half-maximal inhibitory concentration: 80000000 nM
Compound 3: middle estimate off by 1.1-fold (0.06 log units), on the low side; the range from low to high includes it.
By their numbers in this assay, from the lowest: compounds 3 and 1 (each within the scatter of the next); then compound 2.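

In this assay, among the compounds shown here, placing a hydroxy group instead of hydrogen on the aromatic carbon ortho to a hydroxy group and meta to a methoxy group gives a 3.5-fold lower number from compound 2 to compound 3 (0.54 log units; beyond the scatter), the first reading of a single change on this core. The step is modest but beyond the scatter, so this position is not indifferent: with the rest of the molecule unchanged, the added hydroxy group goes with stronger inhibition, although all the numbers remain very high. At this same position, compound 3 with its hydroxy group gives 80000000 nM and compound 1 with a methoxy group gives 85000000 nM, and these values lie within the scatter of each other, so the two groups cannot be told apart in this test.

Going by these compounds, it remains open whether a different group at this position, such as an amine, a carboxylic acid or a longer chain, would give a lower number or a higher one. Also open is why the hydroxy group has this effect, as no measurement here addresses the reason for the step.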